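The source may report more compounds than this note shows. Statements on the series, on what has been measured and on what is new or still open speak of the compounds shown alone.

Measured so far in an assay on isolated protein (Cricetulus griseus) for binding affinity to Alpha-1B adrenergic receptor (Mesocricetus auratus), read by radioligand binding; on this read-out lower numbers stand for stronger inhibition and higher numbers for weaker inhibition:
compound 1 `Oc1cccc2c1CCCC2c1c[nH]cn1`, 145 nM
compound 2 `CCS(=O)(=O)Nc1cccc2c1CCCC2c1c[nH]cn1`, 1320 nM
compound 3 `CC(C)S(=O)(=O)Nc1cccc2c1CCCC2c1c[nH]cn1`, < 10000 nM

For compound 3 the figure is a limit of the assay and not a number (the limit of < 10000 nM in this assay, at which 1 of the 3 values shown sits). Compound 3 therefore stands apart from compound 1 and compound 2, both of which give readable numbers. Compound 4 `Nc1cccc2c1CCCC2c1c[nH]cn1` is not yet measured; it differs from compound 3 by hydrogen in place of isopropylsulfonyl on a nitrogen on an aromatic ring. The steps a step that the limit leaves unreadable from compound 1 to compound 3 and a step that the limit leaves unreadable from compound 2 to compound 3 cannot be sized. Among the compounds with values here, the one readable step, a 9.1-fold higher number from compound 1 to compound 2 (0.96 log units; beyond the scatter), shows the (ethylsulfonyl)amino compound giving the higher number than the hydroxy compound; compound 4 carries amino, a group without the sulfonyl, and so is expected to sit nearer compound 1 than compound 2. Compound 4 is expected near 300 nM, between 60 nM and 1500 nM. The step that the limit leaves unreadable from compound 3 to compound 4 is expected to remain unreadable from a limit.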

Compound 4, inhibition constant: 525 nM
Compound 4: middle estimate off by 1.8-fold (0.24 log units), on the low side; low and high end bracket the measured number.
By their numbers in this assay, from the lowest: compound 1; then compound 4; then compound 2.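

In this assay, hydrogen in place of ethylsulfonyl on the nitrogen gives a 2.5-fold lower number from compound 2 to compound 4 (0.40 log units; beyond the scatter), so the number falls once the sulfonyl group is gone. Amino in place of hydroxy still gives a 3.6-fold higher number from compound 1 to compound 4 (0.56 log units; beyond the scatter), so the bare amino does not return the series to the hydroxy compound. Compound 3 carries a limit and not a number, so its steps to the other compounds cannot be read: the limit of < 10000 nM in this assay, at which 1 of the 4 values shown sits.

Open, from the compounds shown here alone, is where a methoxy group or an acetyl amide at this place would fall relative to hydroxy and amino. Also open, going by these compounds, is whether a methylsulfonyl group on the nitrogen would track the ethylsulfonyl compound.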